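The compounds below may be only part of what the source reports. "The series", "measured", "known", "first", "only" and "open" are said of these compounds alone.

Measured compounds:
- Compound 1, `Clc1cccc(/N=N/N2CCCCC2)c1`: in an ADME assay on BHK-21 cells (Mesocricetus auratus) for cytotoxicity, read by MTT assay, with a stated time of 96 h (a higher number here means that more compound is tolerated, a lower number that less compound is tolerated), compound 1 gives > 100000 nM, which is a limit of the assay, not a number.
- Compound 2, `c1ccc(/N=N/N2CCCCC2)cc1`: in this assay compound 2 gives > 100000 nM, again a limit.
- Compound 3, `Clc1ccc(/N=N/N2CCCC2)cc1`: in this assay compound 3 gives > 100000 nM, also a limit.

All three values sit at the limit of > 100000 nM in this assay, at which 3 of the 3 values shown sit. From compound 2 to compound 1 the change is chloro in place of hydrogen on an aromatic carbon, and the step that the two limits leave unreadable from compound 2 to compound 1 stays unreadable, since both ends are limits. Compound 4, `Clc1ccc(/N=N/N2CCCC2)cc1Cl`, is not yet measured. It differs from compound 3 by chloro in place of hydrogen on an aromatic carbon, the same kind of change as from compound 2 to compound 1, though here the entering chloro sits ortho to a chloro group and meta to a group of 7 heavy atoms, while in compound 1 it sits meta to a group of 8 heavy atoms. The difference between the cores of compound 3 and compound 2 is not broken down here. For the measured compounds named here, the step from compound 3 to compound 4 is expected to be a number no higher from compound 3 to compound 4 (the limit leaves the size open), because every value so far sits at the limit of > 100000 nM in this assay, at which 3 of the 3 values shown sit. Compound 4 is therefore estimated at 100000 nM, most likely again reported only as a limit.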

Compound 4, half-maximal cytotoxic concentration: 50000 nM
Beside the measured number, compound 4's estimate is 2.0-fold (0.30 log units) above it; measured number inside the range.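

In this assay, chloro in place of hydrogen on an aromatic carbon gives an at least 2.0-fold lower number from compound 3 to compound 4 (0.30 log units; that floor lies within the scatter), so even this smallest possible size does not stand clear of the usual scatter. The same change on the core of compound 2 cannot be read, since both of its ends are limits and not numbers: the limit of > 100000 nM in this assay, at which 3 of the 4 values shown sit. This means that the change has one readable case, which cannot show whether its effect carries from one core to another.

The compounds shown leave open what an amine or a carboxylic acid would do in place of this chloro in this assay. From the compounds shown here alone, how far the true step goes past its floor also stays open.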